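A few compounds are considered here, and "the series" means these few. Any claim that something is new, unique, unknown or untested is made for them only; others in the source may bear on it.

Compound 3 `COc1cc(C)c(Cl)cc1C1=NN(c2ccc(S(N)(=O)=O)cc2)C(c2cccc(O)c2)C1` gives 16.7% in a functional assay on the whole organism (strain Wistar) for inhibition, with Rattus norvegicus as the target, read by paw edema, with stated times of 30 min and 5 h, at a dose of 20 mg/kg by the oral route (a lower number here means less inhibition, a higher number more inhibition at the dose given (going by the name of the read-out)), and stands lowest of the three numbers measured: compound 1 `Cc1cc(O)c(C2=NN(c3ccc(S(N)(=O)=O)cc3)C(c3ccccc3O)C2)cc1Cl` gives 59.5% and compound 2 `Cc1cc(O)c(C2=NN(c3ccc(S(N)(=O)=O)cc3)C(/C=C/c3ccccc3)C2)cc1Cl` gives 71.4%, each beyond the scatter above compound 3. For the measured compounds named here, the only step measured in one place, a number 11.9 percentage points higher from compound 1 to compound 2 (beyond the scatter), changes the group on the saturated ring carbon, the same place altered here, but neither group in that step matches the change now made. Compound 4 `COc1cc(C)c(Cl)cc1C1=NN(c2ccc(S(N)(=O)=O)cc2)C(c2ccc(OC)c(OC)c2OC)C1` carries 2,3,4-trimethoxyphenyl in place of 3-hydroxyphenyl on a saturated ring carbon. Going by the values given here, no measured step covers a trimethoxyphenyl at this place, so the expectation rests on the low starting point of compound 3 and on the modest size of the one step at this position. A step of a number 8.3 percentage points higher from compound 3 to compound 4 (within the scatter) is expected, small and uncertain in direction. For compound 4 the estimate in this assay is 25%, with a range from 5% to 50%.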

Compound 4, a percentage reported as inhibition, in the whole organism at one dose (the size of the read-out at that dose, not a potency): 21.4%
Compound 4: the middle estimate sits 3.6 percentage points above what was measured; low and high end bracket the measured number.
By their numbers in this assay, from the lowest: compounds 3 and 4 (each within the scatter of the next); then compound 1; then compound 2.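

With 2,3,4-trimethoxyphenyl in place of 3-hydroxyphenyl on the saturated ring carbon, this assay gives a number 4.7 percentage points higher from compound 3 to compound 4 (within the scatter). On this core, therefore, the two groups are not told apart by this read-out, although the entering group has no hydrogen-bond donor and more heavy atoms. Nothing available explains this result.

For the compounds shown here, still open is how the 5-chloro-2-methoxy-4-methylphenyl group bears on the read-out, as no single-place step covers it. Also open, as far as these compounds go, is whether an aminomethyl or carboxylic acid group on this phenyl ring would give a step beyond the scatter.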